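A few compounds are considered here, and "the series" means these few. Any claim that something is new, unique, unknown or untested is made for them only; others in the source may bear on it.

Compound 3, with the structure `Cc1cc(-c2nc(C(c3ccc(F)cc3)c3ccc(F)cc3)sc2CC(=O)O)cnc1N`, is measured in an in vitro functional assay on HEK285-7 cells for antagonist activity at prostaglandin D2 receptor 2 (Homo sapiens), read by BRET and beta-arrestin recruitment (on this read-out higher numbers stand for larger maximal responses and lower numbers for smaller maximal responses), and gives 80%. It stands level with the two other measured compounds: compound 1, `O=C(O)Cc1sc(C(c2ccc(F)cc2)c2ccc(F)cc2)nc1-c1ccoc1`, gives in this assay 80%, and compound 2, `O=C(O)Cc1sc(C(c2ccc(F)cc2)c2ccc(F)cc2)nc1-c1cc(F)nc(F)c1`, gives 80%. The step from compound 1 to compound 2 is no change at the digits printed from compound 1 to compound 2 (within the scatter), the step from compound 1 to compound 3 is no change at the digits printed from compound 1 to compound 3 (within the scatter), and the step from compound 2 to compound 3 is no change at the digits printed from compound 2 to compound 3 (within the scatter). All three therefore show that exchanging the aryl group at this position of the shared core has so far left the maximal response untouched.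

Compound 4, `Cc1cc(-c2nc(C(c3ccc(F)cc3)c3ccc(F)cc3)sc2CC(=O)O)ccn1`, is not yet measured. Its difference from compound 3 is this: 2-methylpyridin-4-yl in place of 6-amino-5-methylpyridin-3-yl on an aromatic carbon. Going by the values given here, every measured step bearing on it, namely each exchange of one aryl group for another at the same place, was within the scatter, so no step beyond the scatter is expected here in either direction, although none of the measured compounds carries this particular group.

The step from compound 3 to compound 4 is therefore expected to be no change at the digits printed from compound 3 to compound 4 (within the scatter). For compound 4 the estimated value in this assay is 80%, with a range from 66% to 94%.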

Compound 4, largest response reached (reported as efficacy), in percent of the reference or control that the assay uses: 80%
Estimate against measurement, compound 4: no gap at the digits printed; the range from low to high includes it.
By their numbers in this assay, from the lowest: compounds 1, 2, 3 and 4 (each within the scatter of the next).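

In this assay, the exchange of 6-amino-5-methylpyridin-3-yl, with 1 hydrogen-bond donor, for 2-methylpyridin-4-yl, with 0 hydrogen-bond donors, is no change at the digits printed from compound 3 to compound 4 (within the scatter) and so leaves the maximal response level. The new group also matches the other two groups at this place, the step being no change at the digits printed from compound 2 to compound 4 (within the scatter) for 2,6-difluoropyridin-4-yl and no change at the digits printed from compound 1 to compound 4 (within the scatter) for furan-3-yl. All four aromatic groups on this carbon, next to the ring nitrogen and next to the ring atom that bears the carboxymethyl group, now stand within the scatter of one another, and nothing shown explains why the maximal response stays level.

As far as these compounds go, all four compounds carry an aromatic ring at this place, so it remains open whether a saturated amine such as piperidine, a longer alkyl chain or a carboxylic acid there would keep the same maximal response. The carboxymethyl group and the large group on the shared core are also the same throughout, so these compounds cannot tell whether the response would stay level if either of them were exchanged.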